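The source may hold more compounds than are shown below. What is called first, only, known or untested is meant among the compounds shown, and "the series" means these compounds.

Working notes on the series, measured in an assay on isolated protein for binding affinity to 5-hydroxytryptamine receptor 1B (Homo sapiens); a lower number here means a stronger inhibitor, a higher number a weaker inhibitor.

Two compounds share the core and carry the measurement. Compound 1, `COc1cc2c(cc1N1CCN(C)CC1)N(C(=O)c1ccc(-c3cccc(C)n3)c3ccccc13)CC2`, gives 2 nM in this assay. Compound 2, `COc1cc2c(cc1N1C[C@@H](C)N(C)[C@@H](C)C1)N(C(=O)c1cccc(Cl)c1Cl)CC2`, gives 12.6 nM in this assay. Of these two numbers compound 2 holds the higher one, and the gap between compound 1 and compound 2 lies beyond the usual scatter of the measurement; the two differ in more than one place, so no single-point step can be read from them.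

Compound 3, `COc1cc2c(cc1N1C[C@@H](C)N(C)[C@@H](C)C1)N(C(=O)Nc1cccc(Cl)c1F)CC2`, is not yet measured. It differs from compound 2 in one place: (3-chloro-2-fluorophenyl)amino in place of 2,3-dichlorophenyl on a carbonyl carbon. The carbonyl thereby becomes part of a urea rather than an amide, and one hydrogen-bond donor enters. Among the measured compounds shown here, no pair in the data separates this kind of change from others, so the expectation for compound 3 rests on the number of compound 2 alone. The step from compound 2 to compound 3 is expected to be a small rise in the number, a 1.6-fold higher number from compound 2 to compound 3 (0.20 log units; within the scatter), close to the edge of the scatter rather than clearly beyond it. Compound 3 is accordingly estimated at 20 nM in this assay, within a range of 6 nM to 65 nM.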

Compound 3, inhibition constant: 7.94 nM
Estimate against measurement, compound 3: 2.5-fold (0.40 log units) above; the range from low to high includes it.
By their numbers in this assay, from the lowest: compound 1; then compounds 3 and 2 (each within the scatter of the next).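

In this assay, replacing 2,3-dichlorophenyl with (3-chloro-2-fluorophenyl)amino on a carbonyl carbon gives a 1.6-fold lower number from compound 2 to compound 3 (0.20 log units; within the scatter) and turns the amide into a urea, so this position accepts that change, with its added hydrogen-bond donor, without a shift in the number beyond the scatter. Among the compounds shown here, this is the first single-place step and the first reading at this position, which the gap between compounds 1 and 2, differing in more than one place, could not provide. Nothing measured here explains why the number holds across this change.

The step alters the link to the ring and the halogen pattern together, so the contribution of each cannot be separated, and 2,3-dichlorophenylamino or 3-chloro-2-fluorophenyl on the same carbonyl carbon would be needed to pull them apart. Also open, as far as these compounds go, is how the position responds to groups further from these two, such as a cyclohexylamino group, a morpholine or a carboxylic acid on the aromatic ring.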